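Bromopyridyl ether swap on a piperidine amide

The compounds below may be only part of what the source reports. "The series", "measured", "known", "first", "only" and "open" are said of these compounds alone.

Compound 2 `Cc1cccc(O[C@@H]2CC[C@@H](C)N(C(=O)c3ccccc3-n3nccn3)C2)n1` is the starting point of this step. Going by the values given here, in a functional assay on CHO-K1 cells for antagonist activity at Orexin receptor type 2 (Homo sapiens), read by FLIPR and calcium flux (on this read-out lower numbers stand for stronger inhibition and higher numbers for weaker inhibition), compound 2 gives 33 nM, the highest of the two numbers measured so far, with compound 1 `COC(=O)c1ccnc(O[C@@H]2CC[C@@H](C)N(C(=O)c3ccccc3-n3nccn3)C2)c1` nearest to it. In this assay compound 1 gives 22 nM. Among the compounds with values here, the only measured step, a 1.5-fold higher number from compound 1 to compound 2 (0.18 log units; within the scatter), lies within the scatter, and it is also the only step that exchanges the group on the oxygen on a saturated carbon, which is the place that changes here. Compound 3 `C[C@@H]1CC[C@@H](Oc2cc(Br)ccn2)CN1C(=O)c1ccccc1-n1nccn1` differs from compound 2 in one place: 4-bromopyridin-2-yl in place of 6-methylpyridin-2-yl on an oxygen on a saturated carbon. Within the data shown here, since the one comparable exchange left the read-out within the scatter, the step from compound 2 to compound 3 is expected to stay within the scatter as well, a 1.1-fold lower number from compound 2 to compound 3 (0.04 log units; within the scatter). The estimate for compound 3 is therefore 30 nM, with a range from 12 nM to 80 nM.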

Compound 3, half-maximal inhibitory concentration: 10 nM
Compound 3: the middle estimate sits 3.0-fold (0.48 log units) above what was measured; the measured number lies below the stated range.
By their numbers in this assay, from the lowest: compound 3; then compounds 1 and 2 (each within the scatter of the next).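

In this assay the group on the oxygen on a saturated carbon now moves the read-out beyond the scatter, with a 3.3-fold lower number from compound 2 to compound 3 (0.52 log units; beyond the scatter) as a modest step when 4-bromopyridin-2-yl replaces 6-methylpyridin-2-yl. Bromo in place of methoxycarbonyl on an aromatic carbon gives a 2.2-fold lower number from compound 1 to compound 3 (0.34 log units; beyond the scatter) as a second modest step beyond the scatter, so compound 3 stands apart from both earlier compounds, which remain within the scatter of each other. Nothing available explains either step.

The compounds shown leave open whether the lower number is tied to bromo itself or would hold for a chloro or an amino group on the same aromatic carbon. They also leave open whether the same exchange would give a similar step on a different amide group of the shared core.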